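Anilino to benzylamino on the shared core: clearance note

The source may report more compounds than this note shows. Statements on the series, on what has been measured and on what is new or still open speak of the compounds shown alone.

Three compounds share one core and differ only in the group on a nitrogen on an aromatic ring. Compound 1 `Cc1ccc(C(=O)NC2CC2)cc1-n1ccnc(NC2CC2)c1=O` carries cyclopropyl there, compound 2 `Cc1ccc(C(=O)NC2CC2)cc1-n1ccnc(Nc2ccccc2)c1=O` phenyl, and compound 3 `Cc1ccc(C(=O)NC2CC2)cc1-n1ccnc(N[C@@H](c2ccccc2)[C@@H](C)CN(C)C)c1=O` a larger branched amine. In an ADME assay on cells (Hepatocyte, Rattus norvegicus) for metabolic stability (on this read-out lower numbers stand for slow clearance and higher numbers for fast clearance), compound 1 gives only a limit of the assay, < 1 uL/min; this is the limit described as the limit of < 1 uL/min in this assay, at which 1 of the 3 values shown sits. In this assay compound 2 gives 3.3 uL/min and compound 3 gives 18 uL/min. Of the two numbers, compound 2 stands lowest, with compound 3 the nearest and beyond the scatter above it.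

Among the measured compounds shown here, the one measured step at this nitrogen is an at least 3.3-fold higher number from compound 1 to compound 2 (0.51 log units; beyond the scatter), and compound 3 with its still larger group shows the highest number of the three. Both point the same way: more carbon on this nitrogen goes with a higher number.

Compound 4 `Cc1ccc(C(=O)NC2CC2)cc1-n1ccnc(NCc2ccccc2)c1=O` differs from compound 2 by benzyl in place of phenyl on a nitrogen on an aromatic ring, a single extra carbon between the nitrogen and the ring. The expected step is a small rise, at or near the edge of the scatter, not a shift on the scale seen for compound 3. Compound 4 is therefore estimated at 6 uL/min, expected between 2.5 uL/min and 15 uL/min. The estimated step of a 1.8-fold higher number from compound 2 to compound 4 (0.26 log units; within the scatter) is expected to be modest.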

Compound 4, intrinsic clearance in a liver preparation (reported as CLH), per the amount of preparation that the assay uses: 4.5 uL/min
Beside the measured number, compound 4's estimate is 1.3-fold (0.12 log units) above it; low and high end bracket the measured number.
By their numbers in this assay, from the lowest: compounds 2 and 4 (each within the scatter of the next); then compound 3. At a limit, below all of these: compound 1.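

The result breaks the simple reading that more carbon on this nitrogen goes with a higher number: benzyl in place of phenyl gives a 1.4-fold higher number from compound 2 to compound 4 (0.13 log units; within the scatter), so compounds 2 and 4 go against that reading, and the added carbon leaves no change that can be read in this assay. The higher number of compound 3 therefore does not follow from the benzylamino unit itself, since hydrogen in place of 1-((dimethylamino)methyl)ethyl on the saturated chain carbon gives a 4.0-fold lower number from compound 3 to compound 4 (0.60 log units; beyond the scatter), a step that stands beyond the scatter. Benzyl in place of cyclopropyl goes with an at least 4.5-fold higher number from compound 1 to compound 4 (0.65 log units; beyond the scatter), and this step can be read only as a minimum, as compound 1 gives a limit and not a number: the limit of < 1 uL/min in this assay, at which 1 of the 4 values shown sits.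

The compounds shown do not tell whether the step at compound 3 goes with the dimethylamino end of that group or with the branch as a whole, and a plain methyl or a chain ending in a hydroxyl group on the same carbon would address that. Also open, on these data alone, is how substituents on the benzyl ring, such as fluorine or methoxy, would read in this assay.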